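Swapping trifluoromethyl for chloro in an antiproliferative series

The source may report more compounds than this note shows. Statements on the series, on what has been measured and on what is new or still open speak of the compounds shown alone.

Compound 1 `COc1cc2ncnc(Nc3ccc(Cl)cc3)c2cc1OCCCCC(=O)Nc1ccc(S(N)(=O)=O)cc1` gives > 40000 nM
Compound 2 `NS(=O)(=O)c1ccc(NC(=S)Nc2ccc3ncnc(Nc4cccc(C(F)(F)F)c4)c3c2)cc1` gives 10100 nM

Only two results exist so far, both from a functional assay on A549 cells (Homo sapiens) for antiproliferative activity, read by MTT assay, with a stated time of 72 h; on this read-out lower numbers stand for stronger inhibition and higher numbers for weaker inhibition. Compound 1 gives > 40000 nM, which is a limit of the assay and not a number. Going by the values given here, compound 2 gives 10100 nM, and this is the only true number available, so nothing yet shows how far a single small change can move the result.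

Compound 3 `NS(=O)(=O)c1ccc(NC(=S)Nc2ccc3ncnc(Nc4cccc(Cl)c4)c3c2)cc1` is the close relative of compound 2 . Among the compounds with values here, its one structural change is chloro in place of trifluoromethyl on an aromatic carbon. That carbon belongs to a six-membered aromatic ring of carbon only, and the swapped group sits meta to a large group. The rest of the molecule stays the same.

Within the data shown here, no measured pair shows what this swap does, so the estimate starts from compound 2 at 10100 nM. The estimated step of a 1.0-fold lower number from compound 2 to compound 3 (0.00 log units; within the scatter) is expected to stay within the usual scatter, with no clear direction. For compound 3 the expected value is 10000 nM, with an estimated range from 4000 nM to 28000 nM.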

Compound 3, half-maximal inhibitory concentration: > 40000 nM
Compound 3 gave a limit, no number (the forecaster's own chance of this, stated with the estimate: 15%); at least 4.0-fold (0.60 log units) between middle value and limit.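

In this assay, going by these compounds alone, trading trifluoromethyl for chloro on this aromatic carbon gives an at least 3.9-fold higher number from compound 2 to compound 3 (0.59 log units; beyond the scatter), the first evidence that one small swap can move the result beyond the scatter. Within the data shown here, the group at this place therefore matters, and in this pair the trifluoromethyl compound is the one with a measurable value, while compound 3 gives > 40000 nM, which is a limit of the assay and not a number. The full size of the step cannot be read because the value of compound 3 stops at that limit: the limit of > 40000 nM in this assay, at which 2 of the 3 values shown sit.

The compounds shown do not tell whether trifluoromethyl itself is special at this place or whether chloro is simply a poor choice there, since a plain hydrogen, a methyl, a bromo, a methoxy or a nitrile in the same spot would be needed to separate those readings. Compound 1 differs from the other two in more than one place, so it cannot show whether the same swap would have a similar effect elsewhere in the series.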